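From 1,3-benzothiazol-2-yl to 1,3-benzoxazol-2-yl in compound 4

A few compounds are considered here, and "the series" means these few. Any claim that something is new, unique, unknown or untested is made for them only; others in the source may bear on it.

In an ADME assay on HEK293 cells (Homo sapiens) for cytotoxicity, with a stated time of 72 h (a lower number here means that less compound is needed, a higher number that more compound is needed for the effect), compound 3 (`O=C(Nc1cccc(-c2nc3ccccc3s2)c1)c1cc([N+](=O)[O-])ccc1Cl`) reaches only the limit > 27000 nM and has no exact number. Compound 4 (`O=C(Nc1cccc(-c2nc3ccccc3o2)c1)c1cc([N+](=O)[O-])ccc1Cl`) has 1,3-benzoxazol-2-yl in place of 1,3-benzothiazol-2-yl on an aromatic carbon. The same 1,3-benzoxazol-2-yl occurs in compound 1 (`O=C(Nc1ccc(F)c(-c2nc3ccccc3o2)c1)c1cc([N+](=O)[O-])ccc1Cl`), which gives only the limit > 25000 nM in this assay. It also occurs in compound 2 (`COc1ccc(-c2nc3ccccc3o2)cc1NC(=O)c1cc([N+](=O)[O-])ccc1Cl`), which likewise gives only the limit > 25000 nM in this assay. Among the measured compounds shown here, no measured pair isolates this swap. The estimated step of a number no higher from compound 3 to compound 4 (the limit leaves the size open) is expected to stay within the usual scatter, with no direction favoured. Compound 4 is estimated at 27000 nM with 13000 nM to 55000 nM as the expected range.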

Compound 4, half-maximal effective concentration: > 25000 nM
Compound 4: a limit, no number (the forecaster's own chance of this, stated with the estimate: 85%); the middle value lies beyond the limit too.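

Among the compounds shown here, no step from compound 1, compound 2 or compound 3 to compound 4 can be read in this assay: all four results are limits, not numbers. The compounds shown leave open what exact concentration any of them needs for the effect, and whether any of these single changes alters it.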